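The source may report more compounds than this note shows. Statements on the series, on what has been measured and on what is new or still open speak of the compounds shown alone.

Measured compounds:
compound 1 `CCCCCCCCCCn1c(=O)n(CCCCN2CCN(c3ccc(F)cc3)CC2)c2ccccc21` gives 724 nM in an assay on membranes from brain for displacement of a labelled ligand from Sigma non-opioid intracellular receptor 1 (Rattus norvegicus), read by radioligand binding, with a stated time of 120 min; a lower number here means a stronger inhibitor, a higher number a weaker inhibitor
compound 2 `CC(=O)c1ccc2c(c1)n(C)c(=O)n2CCCCN1CCN(c2ccc(F)cc2)CC1` gives 72.3 nM in this assay
compound 3 `CCCCCn1c(=O)n(CCCCN2CCN(c3ccc(F)cc3)CC2)c2ccc(C(C)=O)cc21` gives 299 nM in this assay

Among these three, compound 3 holds the middle position: it lies below compound 2, which gives the lowest number, and above compound 1, which gives the highest number. Compound 4 `CCCCCCCCCCn1c(=O)n(CCCCN2CCN(c3ccc(F)cc3)CC2)c2ccc(C(C)=O)cc21` has not yet been measured. It differs from compound 3 by pentyl in place of hydrogen on a saturated chain carbon, five bonds along the chain from an aromatic nitrogen, so that the chain on the core of compound 3 is extended further. Among the measured compounds shown here, only one measured step bears on this kind of change: a 4.1-fold higher number from compound 2 to compound 3 (0.62 log units; beyond the scatter), in which the same chain was lengthened and the number rose. Compound 1, which carries the same long chain as compound 4 but lacks the acetyl group, gives a number above that of compound 3. On this basis a further weakening is expected for compound 4, of a size comparable to a 2.3-fold higher number from compound 3 to compound 4 (0.37 log units; beyond the scatter). Compound 4 is therefore estimated to give 700 nM in this assay, with a range from 250 nM to 2000 nM.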

Compound 4, inhibition constant: 988 nM
Estimate against measurement, compound 4: 1.4-fold (0.15 log units) below; measured number inside the range.
By their numbers in this assay, from the lowest: compound 2; then compound 3; then compounds 1 and 4 (each within the scatter of the next).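

In this assay the number keeps rising as the chain grows on the acetyl-bearing core, with a 4.1-fold higher number from compound 2 to compound 3 (0.62 log units; beyond the scatter) followed by a 3.3-fold higher number from compound 3 to compound 4 (0.52 log units; beyond the scatter) and the whole extension amounting to a 14-fold higher number from compound 2 to compound 4 (1.14 log units; beyond the scatter) across these compounds. The acetyl group does not separate the two compounds that carry the longest chain: a 1.4-fold higher number from compound 1 to compound 4 (0.14 log units; within the scatter) stays within the scatter. Nothing measured here gives a reason for either result.

Going by these compounds, whether a still longer chain would raise the number further, or how a chain ending in an amine or a carboxylic acid would compare, stays open. On these data alone, what the acetyl group does when the chain is shorter, as with methyl or pentyl, also stays open.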